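Nitro-to-amino swap on two trimethoxyphenyl cores

A few compounds are considered here, and "the series" means these few. Any claim that something is new, unique, unknown or untested is made for them only; others in the source may bear on it.

Measured so far:
- compound 1 `COc1ccc(-n2ccnc2-c2cc(OC)c(OC)c(OC)c2)cc1[N+](=O)[O-]`: 600 nM
- compound 2 `COc1ccc(-n2ccnc2-c2cc(OC)c(OC)c(OC)c2)cc1N`: 200 nM
- compound 3 `COc1ccc(OC(=O)c2cc(OC)c(OC)c(OC)c2)cc1[N+](=O)[O-]`: > 100000 nM (a limit of the assay)

In a functional assay on HT-29 cells (Homo sapiens) for antiproliferative activity, read by MTT assay, with a stated time of 72 h (on this read-out lower numbers stand for stronger inhibition and higher numbers for weaker inhibition), compound 1 gives 600 nM and compound 2 gives 200 nM. The change between them is amino in place of nitro on an aromatic carbon and it produced a 3.0-fold lower number from compound 1 to compound 2 (0.48 log units; beyond the scatter). For compound 3 in this assay only a limit is recorded, namely (the limit of > 100000 nM in this assay, at which 1 of the 3 values shown sits). The difference between the core of compound 1 and the core of compound 3 is not broken down here.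

Compound 4 `COc1ccc(OC(=O)c2cc(OC)c(OC)c(OC)c2)cc1N` has not been measured in this assay. It differs from compound 3 by amino in place of nitro on an aromatic carbon, the same change as from compound 1 to compound 2. On the core of compound 1 that change gave a modest step, a 3.0-fold lower number from compound 1 to compound 2 (0.48 log units; beyond the scatter). Applied to compound 3, which sits at the limit, a step of that size would leave compound 4 far weaker than compound 1 or compound 2, and a limit is again possible. For compound 4 the expected step is an at least 1.6-fold lower number from compound 3 to compound 4 (0.22 log units; that floor lies within the scatter). Compound 4 is thus estimated at 60000 nM in this assay, expected to fall between 15000 nM and 200000 nM.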

Compound 4, half-maximal inhibitory concentration: > 100000 nM
Compound 4 ended at the assay's limit (the forecaster's own chance of this, stated with the estimate: 55%); middle value at least 1.6-fold (0.22 log units) away from the limit.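

In this assay compound 3 and compound 4 both stand at a limit rather than at a number, so no step between them can be read: the limit of > 100000 nM in this assay, at which 2 of the 4 values shown sit.

The compounds shown leave open whether amino in place of nitro shifts the number at all on the core of compound 3, as it did on the core of compound 1.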